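The source may hold more compounds than are shown below. What is called first, only, known or untested is meant among the compounds shown, and "the series" means these compounds.

Compound 3 `CCC(=O)Nc1cc(Oc2ccc(Nc3nccc4[nH]cc(-c5ccc(F)cc5)c(=O)c34)cc2F)ccn1` gives 92.1% in a functional assay on MKN-45 cells (Homo sapiens) for antiproliferative activity, read by MTT assay, with a stated time of 72 h, tested at 10 uM (a lower number here means less inhibition, a higher number more inhibition at the concentration tested (going by the name of the read-out)), the second highest of three numbers. Compound 2 `CC(C)C(=O)Nc1cc(Oc2ccc(Nc3nccc4[nH]cc(-c5ccc(F)cc5)c(=O)c34)cc2F)ccn1` gives 95.4% in this assay, within the scatter of compound 3, while compound 1 `O=C(Nc1cc(Oc2ccc(Nc3nccc4[nH]cc(-c5ccc(F)cc5)c(=O)c34)cc2F)ccn1)C1CC1` gives 81.8% in this assay, lower beyond the scatter. Compound 4 `Nc1nccc(Oc2ccc(Nc3nccc4[nH]cc(-c5ccc(F)cc5)c(=O)c34)cc2F)c1Cl` differs from compound 3 by 2-amino-3-chloropyridin-4-yl in place of 2-(propanoylamino)pyridin-4-yl on an oxygen on an aromatic ring. The three measured steps touch only the acyl part of the amide: a number 13.6 percentage points higher from compound 1 to compound 2 (beyond the scatter), a number 10.3 percentage points higher from compound 1 to compound 3 (beyond the scatter) and a number 3.3 percentage points lower from compound 2 to compound 3 (within the scatter). Going by these compounds, none of them removes the amide or brings in a chlorine, so none bears directly on this change, and its direction is unknown. The step is therefore expected to be small, a number 7.1 percentage points lower from compound 3 to compound 4 (within the scatter), with a wide range. Compound 4 is expected at 85%, from 55% to 97%.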

Compound 4, a percentage reported as inhibition, at one concentration (the size of the read-out at that concentration, not a potency): 85.7%
The estimate for compound 4 lay 0.7 percentage points below the measured number; measured number inside the range.
By their numbers in this assay, from the lowest: compounds 1, 4, 3 and 2 (each within the scatter of the next, the first and the last beyond it).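

In this assay the step of a number 6.4 percentage points lower from compound 3 to compound 4 (within the scatter) and the step of a number 9.7 percentage points lower from compound 2 to compound 4 (within the scatter) and the step of a number 3.9 percentage points higher from compound 1 to compound 4 (within the scatter) show that the pyridine group on the oxygen can lose its whole acylamino side and gain a chlorine while staying within the scatter of all three amides. Inhibition at this concentration therefore does not depend on the amide among these compounds. No evidence here accounts for this result.

Going by these compounds, what the free amine and the chlorine each contribute stays open, as they enter together. So does how a methyl or a methoxy in place of the chlorine would read.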